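A few compounds are considered here, and "the series" means these few. Any claim that something is new, unique, unknown or untested is made for them only; others in the source may bear on it.

Measured compounds:
compound 1, `O=C(/N=C(/NC(=O)c1cc(-c2ccccc2)nc2ccccc12)[Se]Cc1ccccc1)c1cc(-c2ccccc2)nc2ccccc12`, 8460 nM
compound 2, `O=C(/N=C(/NC(=O)c1cccs1)[Se]Cc1ccccc1)c1cccs1`, 72500 nM
compound 3, `CS/C(=N\C(=O)c1cccs1)NC(=O)c1cccs1`, 19700 nM

Three compounds have been run in an ADME assay on MCF-10A cells (Homo sapiens) for cytotoxicity, read by MTT assay, with a stated time of 72 h; a higher number here means a weaker inhibitor of growth, a lower number a stronger inhibitor of growth. Compound 1 gives the lowest of the three numbers, 8460 nM. Compound 3 stands nearest to it at 19700 nM, and compound 2 furthest at 72500 nM. Compound 1 and compound 2 carry different cores; the difference between the two cores is not broken down here.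

Within the core of compound 2, one change is measured: a group of 2 heavy atoms (1 carbon, 1 sulfur; no ring) in place of a group of 8 heavy atoms (7 carbon, 1 selenium; one six-membered aromatic ring of carbon only), on a carbon with a double bond to nitrogen. It gives a 3.7-fold lower number from compound 2 to compound 3 (0.57 log units; beyond the scatter).

The unmeasured compound 4, `CS/C(=N\C(=O)c1cc(-c2ccccc2)nc2ccccc12)NC(=O)c1cc(-c2ccccc2)nc2ccccc12`, carries the core of compound 1 with the same change applied: a group of 2 heavy atoms (1 carbon, 1 sulfur; no ring) in place of a group of 8 heavy atoms (7 carbon, 1 selenium; one six-membered aromatic ring of carbon only), on a carbon with a double bond to nitrogen. The two changes sit on the same kind of carbon with the same neighbours, so this is the same change on the other core. It occurs only twice among the compounds shown, and only one of those occurrences is measured, so the expectation for compound 4 rests on a single step.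

Taking the step from compound 2 to compound 3 as the guide, compound 4 is expected to show a 3.4-fold lower number from compound 1 to compound 4 (0.53 log units; beyond the scatter) in this assay, beside the measured 3.7-fold lower number from compound 2 to compound 3 (0.57 log units; beyond the scatter), with a wider range than that single step because only one example supports the transfer between cores. Compound 4 is therefore estimated at 2500 nM in this assay, expected to lie between 800 nM and 8000 nM.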

Compound 4, concentration for 50% growth inhibition: 40 nM
For compound 4 the middle estimate is 63-fold (1.80 log units) above the measured one; measured number outside the range, below it.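

In this assay, putting methylsulfanyl in place of the selenium-bearing group, on a carbon with a double bond to nitrogen whose other neighbours are two amide-type nitrogens, gives a 210-fold lower number from compound 1 to compound 4 (2.33 log units; beyond the scatter). The direction of the change carries from one core to the other, but its size does not, so a step measured on one core is a poor guide to the size of the step on the other: the same change on two cores in this assay, a 3.7-fold lower number (0.57 log units; beyond the scatter) from compound 2 to compound 3 and a 210-fold lower number (2.33 log units; beyond the scatter) from compound 1 to compound 4, 57-fold (1.76 log units) apart, beyond the scatter of two such steps. With one pair on each core, these results show that the size of this step depends on the core, but they do not show which part of the core matters, why the two steps differ, or what the step would be on a third core.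

The compounds shown leave open whether the large step follows the loss of selenium or the loss of the ring, a question that a phenylmethylsulfanyl group or a methylselanyl group on the core of compound 1 would separate. They also leave open whether a longer chain on the sulfur, such as ethylsulfanyl, or an amine at the same carbon would keep a number near that of compound 4, 40 nM.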